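A few compounds are considered here, and "the series" means these few. Any claim that something is new, unique, unknown or untested is made for them only; others in the source may bear on it.

Notes on the series. The three measured compounds carry the same ethoxy-bearing phenyl ring and the same ester on differing cores. Compound 1 `CCOC(=O)c1cc(-c2ccc(OCC)cc2)ccn1` gives 105000 nM in an assay on COS-7 cells for inhibition of patatin-like phospholipase domain-containing protein 2 (Mus musculus); a higher number here means a weaker inhibitor, a lower number a stronger inhibitor. Compound 2 `CCOC(=O)c1cccc(-c2ccc(OCC)cc2)c1` gives 50000 nM in this assay, the lower of the two numbers; compound 1 sits higher, and that gap lies beyond the scatter. Compound 3 `CCOC(=O)C1CCCC(c2ccc(OCC)cc2)N1` returns only a limit in this assay, namely > 200000 nM, which is the limit of > 200000 nM in this assay, at which 1 of the 3 values shown sits.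

Compound 4 `CCOC(=O)c1cccc(-c2ccc(OC)cc2)c1` differs from compound 2 by hydrogen in place of methyl on a saturated chain carbon bound to an oxygen on an aromatic ring, ethoxy to methoxy. Among the compounds with values here, no measured pair in the set shows this change, so nothing in the data sizes it. The ethyl to methyl change is expected to move this assay little, with a slight lean to a higher number that may stay within the scatter. Compound 4 is therefore estimated at 70000 nM, with a range of 25000 nM to 200000 nM. The expected step from compound 2 to compound 4 is a 1.4-fold higher number from compound 2 to compound 4 (0.15 log units; within the scatter).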

Compound 4, half-maximal inhibitory concentration: 80000 nM
Beside the measured number, compound 4's estimate is 1.1-fold (0.06 log units) below it; measured number inside the range.
By their numbers in this assay, from the lowest: compounds 2, 4 and 1 (each within the scatter of the next, the first and the last beyond it). At a limit, above all of these: compound 3.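

Read at this place for the first time, ethoxy to methoxy gives a 1.6-fold higher number from compound 2 to compound 4 (0.20 log units; within the scatter) in this assay, so the pair offers no ground for separating the two groups. Earlier compounds differed in their cores and held the ethoxy group and the ester fixed, so they said nothing about this chain; the reading now available is that removing the methyl leaves compound 4 within the scatter of compound 2. Nothing measured in the series accounts for this step, and the one limit on record does not bear on it.

Going by these compounds, whether a longer chain such as propoxy, or a free hydroxyl in place of the ethoxy group, would give a step beyond the scatter remains open. So does the effect of a carboxylic acid or an amide in place of the ester on the core of compound 2.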